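The compounds below may be only part of what the source reports. "The series", "measured", "known", "first", "only" and "open" are said of these compounds alone.

Working notes on the series. Compound 1 `NS(=O)(=O)c1ccc2nc(-c3ccc(-c4ccccc4F)cc3)[nH]c2c1` and compound 2 `Cc1cccc(-c2ccc(-c3nc4ccc(S(C)(=O)=O)cc4[nH]3)cc2)c1` share a core that carries a sulfonyl group on one side and a biphenyl arm on the other; compound 1 bears an unsubstituted sulfonamide, compound 2 a methylsulfonyl. In an assay on isolated protein for inhibition of acyl-CoA desaturase 1 (Rattus norvegicus) (a lower number here means a stronger inhibitor, a higher number a weaker inhibitor), compound 1 gives 343 nM. In this assay compound 2 gives 319 nM. The two numbers sit within the scatter of each other, so nothing separates compound 2 from compound 1 on the evidence at hand.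

Compound 3 `CS(=O)(=O)c1ccc2nc(-c3ccc(-c4ccccn4)cc3)[nH]c2c1` keeps the methylsulfonyl core of compound 2 and changes the outer ring of the arm: pyridin-2-yl in place of 3-methylphenyl on an aromatic carbon. Among the compounds with values here, no step between two measured compounds in this set touches that outer ring, so no measured precedent fixes the size of the change; the entering group is smaller and brings one hydrogen-bond acceptor where the leaving group has none. The expectation is a step of a 1.6-fold higher number from compound 2 to compound 3 (0.20 log units; within the scatter), modest and toward a higher number, though a result within the scatter of compound 2 would not surprise. Compound 3 is therefore estimated at 500 nM, with a range from 200 nM to 1500 nM.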

Compound 3, half-maximal inhibitory concentration: 1710 nM
Compound 3: middle estimate off by 3.4-fold (0.53 log units), on the low side, outside the stated range (above it).
By their numbers in this assay, from the lowest: compounds 2 and 1 (each within the scatter of the next); then compound 3.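

In this assay, within the data shown here, the outer ring of the arm turns out to be a position where a single change registers: pyridin-2-yl in place of 3-methylphenyl, on an aromatic carbon para to a large group, gives a 5.4-fold higher number from compound 2 to compound 3 (0.73 log units; beyond the scatter), the first step in this set that reads this position directly. The swap changes the ring atom and removes the methyl group together, so the step belongs to the exchange as a whole and cannot be divided between those two features. Nothing at hand bears on why the number rises.

On these data alone, it remains open whether the step follows the ring nitrogen or the missing methyl group: an unsubstituted phenyl on the same core would separate the two, and pyridin-3-yl would show whether the location of the nitrogen in the ring counts. Also open, as far as these compounds go, is whether the same exchange gives a step of similar size on the sulfonamide core of compound 1, and how the outer ring tolerates a larger group such as a morpholine or a carboxylic acid.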